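Pentyl for butoxy on the cyclohexyl compound

The source may report more compounds than this note shows. Statements on the series, on what has been measured and on what is new or still open speak of the compounds shown alone.

Measured in a functional assay on brain (Rattus norvegicus, strain Wistar) for inhibition; a higher number here means a weaker inhibitor, a lower number a stronger inhibitor:
Compound 1 `CCCCOc1ccc(-c2c(C)[nH]c(=O)n2C)cc1`: 5100 nM
Compound 2 `CCCCOc1ccc(-c2c(C)[nH]c(=O)n2C2CCCCC2)cc1`: 13900 nM
Compound 3 `Cc1[nH]c(=O)n(C)c1-c1ccc(OCCC(C)C)cc1`: 6600 nM

Compound 2, at 13900 nM, carries the highest number of the three and is the weakest inhibitor measured so far. Compound 4 `CCCCCc1ccc(-c2c(C)[nH]c(=O)n2C2CCCCC2)cc1` keeps the cyclohexyl group of compound 2 but has pentyl in place of butoxy on an aromatic carbon. Going by the values given here, no measured pair makes this exchange, so the data give no direct size for it, and no measured compound carries pentyl.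

The nearest evidence is a change within the same chain, with methyl in place of hydrogen on a saturated chain carbon bound to two saturated chain carbons, which gave a 1.3-fold higher number from compound 1 to compound 3 (0.11 log units; within the scatter). The other measured step, a 2.7-fold higher number from compound 1 to compound 2 (0.44 log units; beyond the scatter), has cyclohexyl in place of methyl on an aromatic nitrogen. It leaves the chain untouched, and compound 2 and compound 4 share that cyclohexyl group, so it says little here.

In this assay, a step within the scatter is therefore expected, with no direction favoured and with wide margins, given the thin evidence. The expected step is a 1.0-fold higher number from compound 2 to compound 4 (0.00 log units; within the scatter). Compound 4 is estimated at 14000 nM, with an expected range of 5000 nM to 40000 nM.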

Compound 4, half-maximal inhibitory concentration: 10600 nM
Estimate against measurement, compound 4: 1.3-fold (0.12 log units) above; measured number inside the range.
By their numbers in this assay, from the lowest: compounds 1, 3, 4 and 2 (each within the scatter of the next, the first and the last beyond it).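

In this assay, pentyl in place of butoxy on an aromatic carbon, para to a large group, gave a 1.3-fold lower number from compound 2 to compound 4 (0.12 log units; within the scatter). Going by these compounds alone, this is the first measured change at this place that removes the oxygen rather than altering the far end of the chain: the hydrogen-bond acceptor count of the group falls from 1 to 0 while its heavy-atom count stays at 5, and the step still lies within the scatter. With the cyclohexyl group in place, then, the oxygen that joins the chain to the aromatic ring is not required for the inhibition read here, although no measurement bears on why the exchange leaves so little trace.

Pentyl appears here only with cyclohexyl on the aromatic nitrogen, so the compounds shown leave open whether the same exchange would read alike with methyl there. They also leave open how an amine, a carboxylic acid or a longer chain would behave at this place, since every group shown there is a short saturated chain, with or without the oxygen.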